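Swapping halogens on the benzyl group of compound 2

A few compounds are considered here, and "the series" means these few. Any claim that something is new, unique, unknown or untested is made for them only; others in the source may bear on it.

Measured so far:
compound 1, `C[C@H](NC(=O)C(=O)Nc1cccnc1N(C)C)C(=O)N[C@@H](CC(=O)O)C(=O)COc1c(F)c(F)cc(F)c1F`, 27 nM
compound 2, `C[C@H](NC(=O)C(=O)NCc1ccccc1F)C(=O)N[C@@H](CC(=O)O)C(=O)COc1c(F)c(F)cc(F)c1F`, 207 nM

In a functional assay on Jurkat cells (Homo sapiens) (on this read-out lower numbers stand for stronger inhibition and higher numbers for weaker inhibition), compound 2 gives the highest of the two numbers shown; the only neighbour is compound 1, and a 7.7-fold higher number from compound 1 to compound 2 (0.88 log units; beyond the scatter). Compound 3, `C[C@H](NC(=O)C(=O)NCc1cccc(Cl)c1Cl)C(=O)N[C@@H](CC(=O)O)C(=O)COc1c(F)c(F)cc(F)c1F`, differs from compound 2 in one place: 2,3-dichlorophenyl in place of 2-fluorophenyl on a saturated chain carbon bound to an amide-type nitrogen. Going by the values given here, the one measured step concerns a different change, the replacement of 2-(dimethylamino)pyridin-3-yl by 2-fluorobenzyl on an amide-type nitrogen, so it does not bear on an exchange of halogens within a benzyl group. With nothing directly comparable, a step of compound 3 relative to compound 2 is expected to stay within or close to the scatter, in either direction. Compound 3 is therefore expected to give about 170 nM in this assay, with a range from 50 nM to 600 nM, which is an expected step of a 1.2-fold lower number from compound 2 to compound 3 (0.09 log units; within the scatter).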

Compound 3, half-maximal inhibitory concentration: 76 nM
Estimate against measurement, compound 3: 2.2-fold (0.35 log units) above, within the range that was stated.
By their numbers in this assay, from the lowest: compound 1; then compound 3; then compound 2.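

Swapping the halogens on this benzyl group moves the number in this assay beyond the usual scatter (a 2.7-fold lower number from compound 2 to compound 3 (0.44 log units; beyond the scatter)), so the place on the saturated chain carbon bound to an amide-type nitrogen responds even when the phenyl ring stays and only its halogens change. The 2,3-dichlorobenzyl group still does not match the 2-(dimethylamino)pyridin-3-yl group of compound 1 (a 2.8-fold higher number from compound 1 to compound 3 (0.45 log units; beyond the scatter)). Nothing available here accounts for the shift between the 2-fluorophenyl and 2,3-dichlorophenyl groups.

This single step changes both the kind of halogen and how many there are, and the compounds shown cannot separate those two changes. Also open, going by these compounds, is where a benzyl group with no halogen, or one carrying a methoxy group, would fall in this assay relative to these compounds.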